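Chlorine on the Sulfonyl Ring: What to Expect for Compound 4

The compounds below may be only part of what the source reports. "The series", "measured", "known", "first", "only" and "open" are said of these compounds alone.

Compound 1, `O=C(Nc1cnn(-c2ccccc2)c1)c1cccc(NS(=O)(=O)c2ccccc2)c1`: 4320 nM
Compound 2, `Cc1ccc(-n2cc(NC(=O)c3cccc(NS(=O)(=O)c4ccccc4)c3)cn2)cc1`: 1690 nM
Compound 3, `COc1ccc(-n2cc(NC(=O)c3cccc(NS(=O)(=O)c4ccccc4)c3)cn2)cc1`: 18700 nM

Of the compounds shown here, three with a shared core have been tested in a functional assay on MCF7 cells (Homo sapiens) for inhibition, read by MTT assay, with a stated time of 48 h; a higher number here means a weaker inhibitor, a lower number a stronger inhibitor. In this assay compound 1 gives 4320 nM, compound 2 gives 1690 nM, and compound 3 gives 18700 nM. The three differ only on the aromatic ring attached to the pyrazole: a 2.6-fold lower number from compound 1 to compound 2 (0.41 log units; beyond the scatter), a 4.3-fold higher number from compound 1 to compound 3 (0.64 log units; beyond the scatter), and an 11-fold higher number from compound 2 to compound 3 (1.04 log units; beyond the scatter). Compound 3 therefore stands highest of the three numbers, that is, it is the weakest inhibitor measured so far.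

Compound 4, `COc1ccc(-n2cc(NC(=O)c3cccc(NS(=O)(=O)c4ccc(Cl)cc4)c3)cn2)cc1`, is built from compound 3 by a change at the opposite end of the molecule: chloro in place of hydrogen on an aromatic carbon. Cut one bond further out, this reads phenylsulfonyl to (4-chlorophenyl)sulfonyl. Among the compounds with values here, none of the measured steps touches this ring; all of them sit on the other aromatic ring, so they give no direct guide to the size or direction of the new step. With nothing to point either way, the change is expected to leave the number close to that of compound 3, giving a step of a 1.3-fold lower number from compound 3 to compound 4 (0.13 log units; within the scatter) in this assay. Compound 4 is thus estimated at 14000 nM, within a range of 4500 nM to 45000 nM.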

Compound 4, half-maximal inhibitory concentration: 8720 nM
Estimate against measurement, compound 4: 1.6-fold (0.21 log units) above, and the stated range covers the measured number.
By their numbers in this assay, from the lowest: compound 2; then compound 1; then compound 4; then compound 3.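

In this assay, the sulfonyl end of the molecule proves sensitive to substitution: chloro in place of hydrogen gives a 2.1-fold lower number from compound 3 to compound 4 (0.33 log units; beyond the scatter), a modest step, but one beyond the usual scatter. Within the data shown here, all the earlier steps sat on the aromatic ring at the other end, so this is the first sign that the ring of the phenylsulfonyl group also affects the number, with a single chlorine atom para to a large group moving the compound towards stronger inhibition. Nothing among the data shown explains why this change acts in this direction or to this extent.

Chlorine on this ring is seen only against hydrogen and only with the methoxy group of compound 3 at the far end, so it remains open whether the same step would appear with the methyl group of compound 2 or the unsubstituted ring of compound 1. The compounds shown also leave open how this position would respond to a different group in the same place, such as an amine or a carboxylic acid.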